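The source may report more compounds than this note shows. Statements on the series, on what has been measured and on what is new or still open speak of the compounds shown alone.

Measured compounds in an assay on isolated protein with malate dehydrogenase, mitochondrial (Sus scrofa) as the target; a lower number here means a stronger inhibitor, a higher number a weaker inhibitor:
- compound 1 `O=C(O)c1cnc2cc(OCCOc3ccccc3)ccc2c1O`: 60300 nM
- compound 2 `O=C(O)c1cnc2cc(OCCOc3ccc(F)cc3)ccc2c1O`: 18200 nM
- compound 3 `O=C(O)c1cnc2cc(OCCc3ccc(Br)cc3)ccc2c1O`: 2510 nM

Compound 3 gives the lowest of the three numbers in this assay. Its nearest neighbour is compound 2, with the step of a 7.3-fold lower number from compound 2 to compound 3 (0.86 log units; beyond the scatter), and the furthest is compound 1, with the step of a 24-fold lower number from compound 1 to compound 3 (1.38 log units; beyond the scatter); both steps lie beyond the scatter, so compound 3 is the strongest inhibitor among the three.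

Compound 4 `O=C(O)c1cnc2cc(OCCc3ccccc3)ccc2c1O` is the next structure, and it differs from compound 3 by hydrogen in place of bromo on an aromatic carbon. Among the compounds with values here, one measured step bears directly on this: a 3.3-fold lower number from compound 1 to compound 2 (0.52 log units; beyond the scatter), where the phenoxy group gained a fluoro substituent and the number fell modestly. The change from compound 3 to compound 4 runs the opposite way, a halogen leaving an aromatic carbon. The step of a 7.3-fold lower number from compound 2 to compound 3 (0.86 log units; beyond the scatter) involved both the linker and the halogen and so says less on its own. The expectation for compound 4 in this assay is therefore a modest rise in the number, of the order seen from compound 1 to compound 2 but reversed, giving an estimated step of a 3.2-fold higher number from compound 3 to compound 4 (0.50 log units; beyond the scatter). Compound 4 is accordingly estimated at 8000 nM, within a range from 2500 nM to 25000 nM.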

Compound 4, half-maximal inhibitory concentration: 38000 nM
The estimate for compound 4 lay 4.8-fold (0.68 log units) below the measured number; measured number outside the range, above it.
By their numbers in this assay, from the lowest: compound 3; then compound 2; then compounds 4 and 1 (each within the scatter of the next).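

In this assay, within the data shown here, the bromo on the aromatic carbon para to a large group proves to be the main contributor to the strength of compound 3: taking it away gives a 15-fold higher number from compound 3 to compound 4 (1.18 log units; beyond the scatter) and a large step, whereas adding fluoro to the phenoxy ring gave only the modest 3.3-fold lower number from compound 1 to compound 2 (0.52 log units; beyond the scatter) in the one earlier halogen comparison. Among these compounds, without a halogen, the linker no longer separates the compounds, since a 1.6-fold lower number from compound 1 to compound 4 (0.20 log units; within the scatter) leaves phenyl and phenoxy on the chain indistinguishable, while the fluoro of compound 2 keeps that compound ahead, with a 2.1-fold higher number from compound 2 to compound 4 (0.32 log units; beyond the scatter) as the step beyond the scatter. Nothing in the data shown accounts for the size of the bromo step.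

The compounds shown leave open whether chloro, iodo or methyl on the same aromatic carbon would match bromo, or whether the step depends on bromine itself. They also leave open whether bromo on the phenoxy ring of compound 1 would give a step of similar size, and whether a longer chain would keep the gain seen with 4-bromophenyl.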